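This account rests on a few compounds, and the source may have more. Where it says the series, first, only, none or still open, it means among the compounds named here.

Working notes on the series. For the measured compounds named here, compound 2 `COc1cc(-c2nn(-c3cccc(NC(=O)Nc4cc(C(F)(F)F)cc(C(F)(F)F)c4)c3)cc2-c2ccncc2)ccc1Cl` is the one number in this set: in a functional assay on CAKI-1 cells (Homo sapiens) for inhibition, read by sulforhodamine B assay, with a stated time of 48 h (a lower number here means that less compound is tolerated, a higher number that more compound is tolerated), compound 2 gives 49300 nM, and it stands as the only numerical value shown. Compound 1 `O=C(Nc1cccc(-n2cc(-c3ccncc3)c(-c3ccc(Cl)c(O)c3)n2)c1)Nc1cccc(C(F)(F)F)c1` is reported only as a limit of the assay, (the limit of > 32500 nM in this assay, at which 1 of the 2 values shown sits); in this assay compound 1 gives > 32500 nM, which is a limit and not a number. Compound 3 `O=C(Nc1cccc(-n2cc(-c3ccncc3)c(-c3ccc(Cl)c(O)c3)n2)c1)Nc1cc(C(F)(F)F)cc(C(F)(F)F)c1` carries the change (hydrogen in place of methyl on an oxygen on an aromatic ring), that is, methoxy to hydroxy on the 4-chloro-3-methoxyphenyl group, giving 4-chloro-3-hydroxyphenyl; the urea side and the rest of the shared core stay as in compound 2. Going by the values given here, no step between two measured compounds is available, so no direction is known. The step from compound 2 to compound 3 is expected to be small, a 1.1-fold lower number from compound 2 to compound 3 (0.04 log units; within the scatter), not beyond the scatter. In this assay compound 3 is estimated at 45000 nM, between 20000 nM and 100000 nM, because compound 2 gives 49300 nM.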

Compound 3, concentration lethal to 50% of the cells: 26500 nM
Compound 3: the middle estimate sits 1.7-fold (0.23 log units) above what was measured; measured number inside the range.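

In this assay, for the compounds shown here, the first readable step at this position, methoxy to hydroxy on the 4-chloro-3-methoxyphenyl group, is a 1.9-fold lower number from compound 2 to compound 3 (0.27 log units; within the scatter), so exchanging methyl for hydrogen on this oxygen gives no change beyond the scatter. The second step, trifluoromethyl in place of hydrogen on an aromatic carbon, is an at least 1.2-fold lower number from compound 1 to compound 3 (0.08 log units; that floor lies within the scatter), and only this floor can be read. Compound 1 stands as a limit and not a number: the limit of > 32500 nM in this assay, at which 1 of the 3 values shown sits.

On these data alone, the true size of the trifluoromethyl step therefore stays open. As far as these compounds go, it also stays open whether a longer chain such as ethyl on this oxygen, or an amine in place of the hydroxy, would move the number in this assay beyond the scatter.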